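Notes on shortening the imide nitrogen chain in this series

The source may hold more compounds than are shown below. What is called first, only, known or untested is meant among the compounds shown, and "the series" means these compounds.

Measured so far in an assay on isolated protein for inhibition of lysosomal alpha-glucosidase (Rattus norvegicus), read by colorimetric assay; a lower number here means a stronger inhibitor, a higher number a weaker inhibitor:
compound 1, `Cc1ccc(S(=O)(=O)Nc2ccc3c(c2)C(=O)N(CCNc2ccc(O)c(O)c2)C3=O)cc1`, 28800 nM
compound 2, `Cc1ccc(S(=O)(=O)Nc2ccc3c(c2)C(=O)N(CCCCBr)C3=O)cc1`, > 200000 nM

Compound 2 gives only a limit in this assay, > 200000 nM, not a number. Compound 2 therefore stands at the limit of > 200000 nM in this assay, at which 1 of the 2 values shown sits, the weaker end of the two values shown. Going by the values given here, the single measured step, an at least 6.9-fold higher number from compound 1 to compound 2 (0.84 log units; beyond the scatter), runs from a measured number into that limit, so its true size is open-ended.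

Compound 3, `Cc1ccc(S(=O)(=O)Nc2ccc3c(c2)C(=O)N(C)C3=O)cc1`, is not yet measured. It differs from compound 2 by hydrogen in place of 3-bromopropyl on a saturated chain carbon bound to an amide-type nitrogen in a ring. Among the compounds with values here, no measured pair bears directly on this change; the only step in hand concerns the (3,4-dihydroxyphenyl)amino group of compound 1, which compound 3 also lacks. Nothing among the shown values suggests the small methyl of compound 3 would recover what compound 2 lost.

Compound 3 is expected at 300000 nM, range 100000 nM to 1000000 nM, most likely again reported as a limit. The estimated step that the limit leaves unreadable from compound 2 to compound 3 is expected to lie within the scatter.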

Compound 3, half-maximal inhibitory concentration: > 200000 nM
Compound 3 ended at the assay's limit; the forecaster's own chance of this, stated with the estimate: 80%; the middle value does not contradict the limit.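

In this assay compound 3 gives > 200000 nM as a limit of the assay and not as a number. Taking the whole chain off this position gives an at least 6.9-fold higher number from compound 1 to compound 3 (0.84 log units; beyond the scatter) and, like an at least 6.9-fold higher number from compound 1 to compound 2 (0.84 log units; beyond the scatter) before it, this step runs into a limit, so its true size is open-ended; of the three compounds, only compound 1, with its (3,4-dihydroxyphenyl)amino group, gives a measured number. The step between compound 2 and compound 3 cannot be read, so hydrogen and 3-bromopropyl cannot be ordered at this position, and the two compounds share one place in the series: the limit of > 200000 nM in this assay, at which 2 of the 3 values shown sit.

As far as these compounds go, it remains open which part of the group in compound 1 goes with the measured number: the aromatic ring, its two hydroxyl groups or the chain nitrogen. A plain amine or a carboxylic acid on a saturated chain carbon bound to an amide-type nitrogen in a ring, or a longer chain carrying the same (3,4-dihydroxyphenyl)amino group, would begin to separate these parts.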